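Swapping methoxy for fluoro on a weak indole pair

The compounds below may be only part of what the source reports. "The series", "measured", "known", "first", "only" and "open" are said of these compounds alone.

Compound 1 `Cc1noc(-c2cc3cc(F)ccc3[nH]2)n1`: 12400 nM
Compound 2 `COc1ccc2[nH]c(-c3nc(-c4ccc(Cl)cc4)no3)cc2c1`: > 50000 nM

In a functional assay on MCF7 cells (Homo sapiens) for antiproliferative activity, read by WST assay, with a stated time of 72 h (on this read-out lower numbers stand for stronger inhibition and higher numbers for weaker inhibition), compound 1 gives 12400 nM. For compound 2 the assay reports no number, only a limit, > 50000 nM; this is the limit of > 50000 nM in this assay, at which 1 of the 2 values shown sits, so compound 2 stands at the weak end of what is shown. Compound 3 `Fc1ccc2[nH]c(-c3nc(-c4ccc(Cl)cc4)no3)cc2c1` differs from compound 2 by fluoro in place of methoxy on an aromatic carbon. For the measured compounds named here, no measured pair shows this change. The expected step from compound 2 to compound 3 is an at least 1.4-fold lower number from compound 2 to compound 3 (0.15 log units; that floor lies within the scatter), a small gain toward stronger inhibition, not clearly beyond the scatter. Compound 3 is estimated at 35000 nM, with a range from 10000 nM to 100000 nM.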

Compound 3, half-maximal inhibitory concentration: > 50000 nM
Compound 3: a limit, no number; the forecaster's own chance of this, stated with the estimate: 45%; at least 1.4-fold (0.15 log units) between middle value and limit.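

Fluoro in place of methoxy cannot be read as a step, since compound 2 and compound 3 both end at a limit of the assay rather than a number: the limit of > 50000 nM in this assay, at which 2 of the 3 values shown sit.

For the compounds shown here, compound 3 does give the first readable step in this set. It differs from compound 1 in one place. In this assay, 4-chlorophenyl in place of methyl gives an at least 4.0-fold higher number from compound 1 to compound 3 (0.60 log units; beyond the scatter), with fluoro unchanged.

Still open, from the compounds shown here alone, is whether methoxy and fluoro differ at all on this aromatic carbon. An amine or a carboxylic acid there might or might not give a measurable number alongside the 4-chlorophenyl.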